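This account rests on a few compounds, and the source may have more. Where it says the series, first, only, none or still open, it means among the compounds named here.

Measured so far:
- compound 1, `Cc1n[nH]c2ccc(-c3nc4cnc(N5CCN(C)CC5)cn4c3Nc3ccc(I)cc3)cc12` — "not determined" (no result reported) in a functional assay on CWR22R cells (Homo sapiens) for inhibition, with a stated time of 120 h, tested at 10 uM; a higher number here means more inhibition at the concentration tested (going by the name of the read-out), a lower number less inhibition
- compound 2, `Cc1n[nH]c2ccc(-c3nc4cnc(N5CCN(C)CC5)cn4c3Nc3ccc(F)cc3Br)cc12` — 4.41%

Going by the values given here, compound 1 carries no number in this assay, so compound 2 holds the only measured value. In this assay, among the compounds with values here, compound 2 gives 4.41%, a weak effect at the single concentration tested, and with no second number beside it there is no measured step to set a scale.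

Compound 3, `Cc1n[nH]c2ccc(-c3nc4cnc(N5CCN(C)CC5)cn4c3Nc3ccc(Cl)cc3Cl)cc12`, is the next entry and is still to be measured in this assay. The change from compound 2 is 2,4-dichlorophenyl in place of 2-bromo-4-fluorophenyl on a nitrogen on an aromatic ring. Both groups keep the same count of heavy atoms and the same single six-membered aromatic ring with no hydrogen-bond donors or acceptors. For compound 3 the expectation is a step of a number 1.6 percentage points higher from compound 2 to compound 3 (within the scatter), which lies within the usual scatter, with no direction claimed. Compound 3 is therefore estimated at 6%, expected to fall between -8% and 20%.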

Compound 3, a percentage reported as inhibition, at one concentration (the size of the read-out at that concentration, not a potency): 9.53%
The estimate for compound 3 lay 3.5 percentage points below the measured number, within the range that was stated.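

In this assay, going by these compounds alone, 2,4-dichlorophenyl in place of 2-bromo-4-fluorophenyl on a nitrogen on an aromatic ring gives a number 5.1 percentage points higher from compound 2 to compound 3 (within the scatter), the first measured step at this position. This exchange of one halogen pattern for another, at an equal count of heavy atoms, therefore leaves compound 2 and compound 3 indistinguishable, with compound 3 at 9.53% at the single concentration tested. No measured property is available that bears on this result.

Going by these compounds, whether an amine or a carboxylic acid on this phenyl ring, or a cyclohexyl group in its place on the same nitrogen, would give a step beyond the scatter remains open. The two numbers also say nothing about changes elsewhere on the shared core, which is identical in compound 2 and compound 3.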